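The source may report more compounds than this note shows. Statements on the series, on what has been measured and on what is new or still open speak of the compounds shown alone.

Compound 3 `CNC(=O)c1cc(C(=O)N[C@H]2[C@@H]3COC[C@@H]32)cc2c1OC[C@H]2c1ccc(F)cc1` offers no exact number to start from: in a physicochemical assay for solubility (a lower number here means a less soluble compound, a higher number a more soluble compound), compound 3 gives >= 176 ug/mL as a limit of the assay. The two other values available are limits as well. Compound 1 `CNC(=O)c1cc(C(=O)NC2CC2)cc2c1OC[C@H]2c1cccc2[nH]ccc12` gives >= 142 ug/mL as a limit. Compound 2 `CNC(=O)c1cc(C(=O)NC2CC2)cc2c1OC[C@H]2c1cccc(OC)c1` gives >= 161 ug/mL as a limit. No order among the three can be read from these figures. Among the measured compounds shown here, the one measured step is a step that the two limits leave unreadable from compound 1 to compound 2 and it concerns the group on a saturated ring carbon, so it does not test a change on the amide.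

Compound 4 `CNC(=O)c1cc(C(=O)NC2CC2)cc2c1OC[C@H]2c1ccc(F)cc1` differs from compound 3 on an amide-type nitrogen: a group of 3 heavy atoms (3 carbon; one three-membered non-aromatic ring of carbon only) in place of a group of 6 heavy atoms (5 carbon, 1 oxygen; one three-membered non-aromatic ring of carbon only, one five-membered non-aromatic ring with 1 hetero atom), on an amide-type nitrogen is the whole change. For the measured compounds named here, no measured step covers this swap, so its size in this assay has to be judged indirectly. Compound 1 carries the same cyclopropyl group and gives >= 142 ug/mL as a limit. Compound 2 also carries cyclopropyl and gives >= 161 ug/mL as a limit. On that evidence, the estimated step of an at least 1.1-fold lower number from compound 3 to compound 4 (0.04 log units; that floor lies within the scatter) is expected to stay within the usual scatter, in no clear direction. For compound 4 the expected value is 160 ug/mL with an estimated range from 90 ug/mL to 220 ug/mL in this measurement.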

Compound 4, solubility: 40 ug/mL
Compound 4: middle estimate off by 4.0-fold (0.60 log units), on the high side; measured number below the stated range.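

In this assay, among the compounds shown here, the change on the amide-type nitrogen gives the first readable step: cyclopropyl in place of the group holding the five-membered oxygen-containing ring gives an at least 4.4-fold lower number from compound 3 to compound 4 (0.64 log units; beyond the scatter). Cyclopropyl alone does not go with the low number, however, as the group on the saturated ring carbon also matters: 4-fluorophenyl in place of 3-methoxyphenyl gives an at least 4.0-fold lower number from compound 2 to compound 4 (0.60 log units; beyond the scatter), and 4-fluorophenyl in place of 1H-indol-4-yl gives an at least 3.5-fold lower number from compound 1 to compound 4 (0.55 log units; beyond the scatter). Among these four compounds, only compound 4 pairs cyclopropyl with 4-fluorophenyl, and all three steps are floors rather than exact sizes, because the higher partner in each is a limit of the assay, as with compound 3: the limit of >= 176 ug/mL in this assay, at which 1 of the 4 values shown sits.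

The step between compound 1 and compound 2 cannot be read, and the compounds shown do not separate the role of the ring oxygen from that of the size of the group on the amide-type nitrogen. They also leave open how a plain ethyl chain, or a chain ending in an amine, would behave at that nitrogen alongside 4-fluorophenyl.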